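Three Measured Compounds and a Fourth to Estimate

The source may report more compounds than this note shows. Statements on the series, on what has been measured and on what is new or still open speak of the compounds shown alone.

Compound 1, `C/C(=N\NC(=O)c1cccc(S(=O)(=O)N2CCOCC2)c1)c1ccc(O)cc1`, gives 36200 nM in a functional assay on PC-3 cells (Homo sapiens) for antiproliferative activity, read by MTT assay, with a stated time of 72 h; a higher number here means a weaker inhibitor, a lower number a stronger inhibitor.
Compound 2, `CCN(CC)c1ccc(/C=N/NC(=O)c2cccc(S(=O)(=O)N3CCOCC3)c2)c(O)c1`, gives 14000 nM in this assay.
Compound 3, `COc1ccc(/C=N/NC(=O)c2cccc(S(=O)(=O)N3CCOCC3)c2)c(O)c1`, gives 5800 nM in this assay.

Compound 3 stands lowest of the three numbers in this assay: compound 2 sits nearest, and compound 1 furthest away, both beyond the usual scatter. Going by the values given here, the only single-site step among the measured compounds is a 2.4-fold lower number from compound 2 to compound 3 (0.38 log units; beyond the scatter), a change of one group on the same ring that shifts the number by a modest amount.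

Compound 4, `O=C(N/N=C/c1cc(Br)cc(Br)c1O)c1cccc(S(=O)(=O)N2CCOCC2)c1`, differs from compound 3 in one place: 3,5-dibromo-2-hydroxyphenyl in place of 2-hydroxy-4-methoxyphenyl on a carbon with a double bond to nitrogen. Among the compounds with values here, no measured step covers this particular exchange. Within the data shown here, the one step on record, from compound 2 to compound 3, shows that trading a group on this ring moves the number only modestly, so a change of similar or somewhat larger size in either direction seems plausible, with no firm basis for choosing a direction.

Compound 4 is therefore expected to land near compound 3, with an estimate of 4500 nM in this assay and a range from 1200 nM to 17000 nM, which corresponds to an expected step of a 1.3-fold lower number from compound 3 to compound 4 (0.11 log units; within the scatter).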

Compound 4, half-maximal inhibitory concentration: 9700 nM
Beside the measured number, compound 4's estimate is 2.2-fold (0.33 log units) below it, within the range that was stated.
By their numbers in this assay, from the lowest: compounds 3, 4 and 2 (each within the scatter of the next, the first and the last beyond it); then compound 1.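

In this assay the exchange of 2-hydroxy-4-methoxyphenyl for 3,5-dibromo-2-hydroxyphenyl on a carbon with a double bond to nitrogen gives a 1.7-fold higher number from compound 3 to compound 4 (0.22 log units; within the scatter) and so leaves the two compounds indistinguishable in this measurement. The earlier step changed one group on this ring; this one replaces the methoxy with two bromine atoms, a different kind of substitution, and the reading still does not separate from that of compound 3. For this pair, then, the position accepts bromine atoms in place of a methoxy with no readable gain or loss, although a single pair says little about other groups here, and nothing on record offers an explanation for this result.

Every compound shown carries a hydroxy group on this ring, so what happens without it, or with an amine or a carboxylic acid in its place, remains open. Also open, going by these compounds, is whether a single bromine or a chlorine on the ring would read any differently from the two bromine atoms of compound 4.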